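Series notes: sulfanyl link replaced by benzylamino link

A few compounds are considered here, and "the series" means these few. Any claim that something is new, unique, unknown or untested is made for them only; others in the source may bear on it.

Measured compounds:
compound 1 `Nc1cc(N)c2nc(-c3ccccc3)c(Sc3ccc(F)cc3)nc2c1`: 85100 nM
compound 2 `COc1cc(CNc2nc3cc(N)cc(N)c3nc2-c2ccccc2)cc(OC)c1OC`: 49000 nM
compound 3 `CCOC(=O)[C@H](CCC(=O)O)NC(=O)c1ccc(Oc2nc3cc(N)cc(N)c3nc2-c2ccccc2)cc1`: < 100000 nM (a limit of the assay, not a number)

In a functional assay on SF-268 cells (Homo sapiens) for inhibition, read by sulforhodamine B assay, with a stated time of 48 h (a lower number here means that less compound is tolerated, a higher number that more compound is tolerated), compound 1 gives 85100 nM, the higher of the two numbers reported. Compound 2 gives 49000 nM in this assay; the gap to compound 1 is within the usual scatter, so no order between the two can be read from it. For compound 3 this assay reports only a limit, < 100000 nM; one of the three values shown sits at the limit of < 100000 nM in this assay, at which 1 of the 3 values shown sits.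

Compound 4 `Nc1cc(N)c2nc(-c3ccccc3)c(NCc3ccc(F)cc3)nc2c1` has not yet been run in this assay. It differs from compound 1 in one place: (4-fluorobenzyl)amino in place of (4-fluorophenyl)sulfanyl on an aromatic carbon. Among the compounds with values here, no measured pair changes exactly this link, so no measured step can be pointed to. Within the data shown here, compound 2 carries a benzylamino link of the same kind as compound 4 and its number lies within the scatter of compound 1, which is the only guide available.

The step from compound 1 to compound 4 is therefore expected to be small, a 1.4-fold lower number from compound 1 to compound 4 (0.15 log units; within the scatter), not beyond the scatter. Compound 4 is estimated at 60000 nM in this assay, with a range from 25000 nM to 120000 nM.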

Compound 4, concentration lethal to 50% of the cells: 40700 nM
Compound 4: the middle estimate sits 1.5-fold (0.17 log units) above what was measured, and the stated range covers the measured number.
By their numbers in this assay, from the lowest: compounds 4, 2 and 1 (each within the scatter of the next, the first and the last beyond it).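

In this assay the aromatic carbon next to the ring nitrogen now has its first step that can be read on its own: (4-fluorobenzyl)amino in place of (4-fluorophenyl)sulfanyl gives a 2.1-fold lower number from compound 1 to compound 4 (0.32 log units; beyond the scatter) on the shared core. The position therefore registers a change of link, though only by a small margin over the scatter. The swap changes two things at once, since the sulfur gives way to a nitrogen with its hydrogen-bond donor and a carbon is added to the link.

Which of these carries the step stays open, and a (4-fluorophenyl)amino link or a (4-fluorobenzyl)sulfanyl link would separate them. Also open, from the compounds shown here alone, is how a link without the aromatic ring, such as a plain alkyl amine, would read at this position.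

No measurement shown bears on the cause of this step.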